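Swapping the pyridine nitrogen position in an amide series

This account rests on a few compounds, and the source may have more. Where it says the series, first, only, none or still open, it means among the compounds named here.

Three measured compounds share one core and differ only in the group on the carbonyl carbon. Compound 1 `O=C(C1CC1)N1CCCn2nc(COc3ccccc3)cc21` gives 61% in a functional assay on HEK293 cells for positive allosteric modulation of metabotropic glutamate receptor 5 (Homo sapiens), read by calcium flux; a lower number here means a smaller maximal response, a higher number a larger maximal response. Compound 2 `O=C(c1ccc(Cl)cc1)N1CCCn2nc(COc3ccccc3)cc21` gives 68% in this assay, and compound 3 `O=C(c1ccccn1)N1CCCn2nc(COc3ccccc3)cc21` gives 44% in this assay, which is the lowest of the three numbers.

Compound 4 `O=C(c1ccncc1)N1CCCn2nc(COc3ccccc3)cc21` is not yet measured. It differs from compound 3 in this way: pyridin-4-yl in place of pyridin-2-yl on a carbonyl carbon.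

Among the compounds with values here, no measured step swaps one pyridinyl for another, so none bears on this change directly. The steps that end at compound 3 are a number 17 percentage points lower from compound 1 to compound 3 (beyond the scatter) and a number 24 percentage points lower from compound 2 to compound 3 (beyond the scatter), both modest drops. Both leave compound 3 at the bottom, while the step of a number 7 percentage points higher from compound 1 to compound 2 (within the scatter) shows the other two groups within the scatter of each other. Within the data shown here, since moving the nitrogen within the ring has no precedent here, an upward step toward the other groups is expected but not assured: the step of a number 11 percentage points higher from compound 3 to compound 4 (beyond the scatter) is my estimate. Compound 4 is therefore expected to reach 55%, with a range from 38% to 72%.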

Compound 4, largest response reached (reported as percent of maximum), in percent of the reference or control that the assay uses: 51%
For compound 4 the middle estimate is 4 percentage points above the measured one, and the stated range covers the measured number.
By their numbers in this assay, from the lowest: compounds 3, 4, 1 and 2 (each within the scatter of the next, the first and the last beyond it).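

Moving the ring nitrogen is the first change here that keeps the same atoms and only joins them differently, and in this assay the step is a number 7 percentage points higher from compound 3 to compound 4 (within the scatter) so the two pyridine isomers cannot be told apart. The 4-chlorophenyl group still stands apart from pyridin-4-yl, with a number 17 percentage points lower from compound 2 to compound 4 (beyond the scatter) as the step, whereas cyclopropyl does not, with a number 10 percentage points lower from compound 1 to compound 4 (within the scatter) as the step. Both pyridine compounds therefore sit beyond the scatter from compound 2, but only compound 3 also sits beyond it from compound 1.

Nothing shown offers a reason for these numbers. Open too, from the compounds shown here alone, is how pyridin-3-yl, or a pyridine ring carrying an added amine, would behave on this carbonyl carbon.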